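Aryl phosphate series: pyridinyl for phenyl, stability notes

The compounds below may be only part of what the source reports. "The series", "measured", "known", "first", "only" and "open" are said of these compounds alone.

Of the compounds shown here, three have been measured in a physicochemical assay for metabolic stability, read by HPLC; on this read-out lower numbers stand for a shorter-lived compound and higher numbers for a longer-lived compound. Compound 1 `O=c1ccn([C@H]2CC[C@@H](COP(=O)(O)Oc3cccnc3)O2)c(=O)[nH]1` gives 50.2 h. Compound 2 `O=c1ccn([C@H]2CC[C@@H](COP(=O)(O)Oc3ccccc3)O2)c(=O)[nH]1` gives 25.1 h. Compound 3 `Nc1ncnc2c1ncn2[C@H]1CC[C@@H](COP(=O)(O)Oc2ccccc2)O1` gives 36.1 h; its value and that of compound 1 lie within the scatter of each other, as do its value and that of compound 2. The difference between the cores of compound 2 and compound 3 is not broken down here.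

One structural change recurs. Between compound 2 and compound 1 it reads (pyridin-3-yl in place of phenyl on an oxygen), and in this assay it made a 2.0-fold higher number from compound 2 to compound 1 (0.30 log units; within the scatter). Compound 4 `Nc1ncnc2c1ncn2[C@H]1CC[C@@H](COP(=O)(O)Oc2cccnc2)O1` carries the identical change on the core of compound 3: pyridin-3-yl in place of phenyl on an oxygen. The place is the same word for word, so this is the same change made on the other core.

For compound 4 a step of a 1.6-fold higher number from compound 3 to compound 4 (0.21 log units; within the scatter) from compound 3 is expected, resting on the earlier move of a 2.0-fold higher number from compound 2 to compound 1 (0.30 log units; within the scatter), which itself stayed within the scatter. Compound 4 is accordingly estimated at 58 h, with a plausible range from 32 h to 105 h.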

Compound 4, half-life: 64.2 h
Compound 4: middle estimate off by 1.1-fold (0.04 log units), on the low side, within the range that was stated.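

In this assay the change of pyridin-3-yl in place of phenyl on an oxygen now reads as a 1.8-fold higher number from compound 3 to compound 4 (0.25 log units; within the scatter) on one core and as a 2.0-fold higher number from compound 2 to compound 1 (0.30 log units; within the scatter) on the other, so the two printed steps point the same way on both cores shown. For the compounds shown here, both steps stay within the scatter, so this pair does not establish a real gain in half-life on either core; it shows only that nothing so far separates how the change reads on the two cores, and two cores give no rule for the whole series. No measurement at hand speaks to what lies behind these numbers.

The compounds shown leave open whether the same change would read alike on a third core. Also open, on these data alone, is how pyridin-2-yl, pyridin-4-yl, or a phenyl ring carrying an amine or a carboxylic acid would read on an oxygen in this same place.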